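From a Cinnamide to a Benzamide on the Shared Core

This account rests on a few compounds, and the source may have more. Where it says the series, first, only, none or still open, it means among the compounds named here.

Compound 2 `O=C(/C=C/c1ccc(Cl)cc1)Nc1cc(Sc2ncn[nH]2)c(O)c2ccccc12` carries a 2-(4-chlorophenyl)ethenyl group on its amide carbonyl. In a functional assay on PC-3 cells (Homo sapiens) for antiproliferative activity, read by MTT assay, with a stated time of 48 h (on this read-out higher numbers stand for weaker inhibition and lower numbers for stronger inhibition), compound 2 gives > 100000 nM, which is a limit of the assay rather than a measured number. Compound 1 `O=C(/C=C/c1ccccc1)Nc1cc(Sc2ncn[nH]2)c(O)c2ccccc12` differs from it only by hydrogen in place of the chlorine, and in this assay compound 1 gives > 100000 nM, again a limit. The step that the two limits leave unreadable from compound 1 to compound 2 therefore cannot be read; both values sit at the limit of > 100000 nM in this assay, at which 2 of the 2 values shown sit.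

Compound 3 `Cc1cccc(C(=O)Nc2cc(Sc3ncn[nH]3)c(O)c3ccccc23)c1` brings the next change: 3-methylphenyl in place of 2-(4-chlorophenyl)ethenyl on a carbonyl carbon. For the measured compounds named here, no measured step of this kind exists, and the single measured step, hydrogen to chlorine, gave no readable size, so there is nothing to scale an expectation by. Both measured compounds rest at the limit of > 100000 nM in this assay, at which 2 of the 2 values shown sit, so the expected step of an at least 1.2-fold lower number from compound 2 to compound 3 (0.09 log units; that floor lies within the scatter) is taken as small, leaving compound 3 at the weak end of this assay. Compound 3 is estimated at 80000 nM in this assay, with a range from 15000 nM to 300000 nM, and the most likely report is once more a limit.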

Compound 3, half-maximal inhibitory concentration: 59500 nM
Compound 3: the middle estimate sits 1.3-fold (0.13 log units) above what was measured, within the range that was stated.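

For the compounds shown here, compound 3 is the first compound here to give a number rather than a limit in this assay, so changing the group on the carbonyl carbon can bring the shared core into the range where this read-out gives a measured value. With 3-methylphenyl in place of 2-(4-chlorophenyl)ethenyl the result is an at least 1.6-fold lower number from compound 2 to compound 3 (0.22 log units; that floor lies within the scatter), and with 3-methylphenyl in place of 2-phenylethenyl the result is an at least 1.6-fold lower number from compound 1 to compound 3 (0.22 log units; that floor lies within the scatter). Each of these is only a floor, and the true size of either change stays hidden because neither starting compound has a measured number: the limit of > 100000 nM in this assay, at which 2 of the 3 values shown sit.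

This change removes the double bond outside the aromatic ring and brings in a methyl group in a single step, and the compounds shown do not separate these two parts of it. As far as these compounds go, how a plain phenyl group on the carbonyl carbon, or a phenyl group carrying an amine or a carboxylic acid, would read in this assay remains open.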